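Hydroxymethyl on the distal ring of compound 2

The source may hold more compounds than are shown below. What is called first, only, known or untested is meant among the compounds shown, and "the series" means these compounds.

Of the compounds shown here, two have been measured in an assay on cells for displacement of a labelled ligand from prostaglandin E2 receptor EP4 subtype (Homo sapiens), read by scintillation counting; a lower number here means a stronger inhibitor, a higher number a weaker inhibitor. Compound 1 `CC(C)c1oc(C(=O)O)cc1COc1ccc(-c2ccccc2)cc1` gives 3000 nM, and compound 2 `Cc1oc(C(=O)O)cc1COc1ccc(-c2ccccc2)cc1` gives 420 nM. Within the data shown here, the single step between them, a 7.1-fold lower number from compound 1 to compound 2 (0.85 log units; beyond the scatter), leaves compound 2 with the lower of the two numbers. Compound 3 `Cc1oc(C(=O)O)cc1COc1ccc(-c2ccc(CO)cc2)cc1` is not yet measured; it differs from compound 2 by hydroxymethyl in place of hydrogen on an aromatic carbon. Among the measured compounds shown here, the one measured step concerns the group on the shared core and says nothing about the far phenyl, so no measured step bears on this change; the expectation rests on compound 2 alone. Compound 3 is therefore expected to land near compound 2, with a 1.1-fold lower number from compound 2 to compound 3 (0.02 log units; within the scatter) as the estimated step, in either direction and quite possibly within the scatter. Compound 3 is estimated at 400 nM in this assay, with a range from 120 nM to 1500 nM.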

Compound 3, inhibition constant: 3000 nM
Estimate against measurement, compound 3: 7.5-fold (0.88 log units) below; the whole stated range lies below it.
By their numbers in this assay, from the lowest: compound 2; then compounds 1 and 3 (each within the scatter of the next).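

In this assay the far phenyl turns out not to be a neutral place: the change from phenyl to 4-(hydroxymethyl)phenyl gives a 7.1-fold higher number from compound 2 to compound 3 (0.85 log units; beyond the scatter), so adding hydroxymethyl on this aromatic carbon, para to a large group, weakens the inhibitor. Among these compounds, until this result, the only measured step concerned the group on the shared core, a 7.1-fold lower number from compound 1 to compound 2 (0.85 log units; beyond the scatter), and a change at the far phenyl now proves comparable in size to that step. Nothing in the information available explains the loss.

On these data alone, it remains open whether the loss belongs to hydroxymethyl itself or to any group at this place, which a methyl, a methoxy, an aminomethyl or a carboxylic acid there could separate. Also open, as far as these compounds go, is how the same change reads with isopropyl in place of methyl on the shared core.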